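A Bromine Added to a Phenyl Ring on a Weak Core

The source may report more compounds than this note shows. Statements on the series, on what has been measured and on what is new or still open speak of the compounds shown alone.

Compound 3 `Cc1oc2ncnc(Nc3ccccc3)c2c1C(=O)O` carries a free carboxylic acid and an unsubstituted phenyl ring on the shared core. In a functional assay on A549 cells (Homo sapiens) for cytotoxicity, read by MTT assay, with a stated time of 72 h (a lower number here means a stronger inhibitor, a higher number a weaker inhibitor), compound 3 gives 191000 nM, the highest of the three numbers measured. Its nearest neighbour is compound 2 `Cc1cccc(Nc2ncnc3oc(C)c(C(=O)O)c23)c1`, which in this assay gives 100000 nM; the step of a 1.9-fold higher number from compound 2 to compound 3 (0.28 log units; within the scatter) lies within the scatter, so these two cannot be told apart. Compound 1 `Cc1oc2ncnc(Nc3cccc(Br)c3)c2c1C(=O)NCCO` differs from compound 3 at two places; in this assay compound 1 gives 17400 nM.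

The move to compound 4 `Cc1oc2ncnc(Nc3cccc(Br)c3)c2c1C(=O)O` is bromo in place of hydrogen on an aromatic carbon. Among the measured compounds shown here, no measured step isolates this change: the only measured step, a 1.9-fold higher number from compound 2 to compound 3 (0.28 log units; within the scatter), concerns a methyl group and says nothing about a bromo. Compound 1 does carry a bromo on its phenyl ring, but it also carries a hydroxyethyl amide in place of the acid, so its lower number compared with compound 3 cannot be credited to the bromo alone. For compound 4 a modest drop in this assay is therefore expected, a 3.2-fold lower number from compound 3 to compound 4 (0.50 log units; beyond the scatter), held loosely. Compound 4 is estimated at 60000 nM, with a range from 15000 nM to 200000 nM.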

Compound 4, half-maximal inhibitory concentration: 43000 nM
Beside the measured number, compound 4's estimate is 1.4-fold (0.14 log units) above it; measured number inside the range.
By their numbers in this assay, from the lowest: compound 1; then compound 4; then compounds 2 and 3 (each within the scatter of the next).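

In this assay, the bromo can now be read on its own: with the acid kept, going from phenyl to 3-bromophenyl gives a change beyond the scatter (a 4.4-fold lower number from compound 3 to compound 4 (0.65 log units; beyond the scatter)), whereas methyl in place of hydrogen on the same aromatic carbon could not be told apart from it (a 1.9-fold higher number from compound 2 to compound 3 (0.28 log units; within the scatter)). Bromo also separates from methyl on that carbon (a 2.3-fold lower number from compound 2 to compound 4 (0.37 log units; beyond the scatter)), so this position does respond to the group placed there, although the size of the change is modest. With the bromo held fixed, hydroxy in place of (2-hydroxyethyl)amino on the carbonyl carbon gives a step of similar size (a 2.5-fold higher number from compound 1 to compound 4 (0.39 log units; beyond the scatter)), so the lower number of compound 1 is not the work of the bromo alone.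

Nothing available here accounts for why the bromo gives a lower number in this cell assay. Still open, on these data alone, is whether another halogen such as chlorine or iodine, or a larger group such as trifluoromethyl, would move the number further at this carbon, and whether an amine or a longer chain in place of the acid would add to the bromo's step.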